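The source may report more compounds than this note shows. Statements on the series, on what has been measured and on what is new or still open speak of the compounds shown alone.

Working notes on the series. In an assay on CHO cells for binding affinity to corticotropin-releasing factor receptor 1 (Homo sapiens) (a lower number here means a stronger inhibitor, a higher number a weaker inhibitor), compound 3 `CCCN(c1nc(-c2ccc(Cl)cc2)n(C)n1)C(C1CC1)C1CC1` gives 33 nM. Compound 1 `CCCN(c1nc(-c2cc(F)c(Cl)cc2Cl)n(C)n1)C(C1CC1)C1CC1` gives 15 nM in this assay. Within the data shown here, compound 2 `CCCN(CC1CC1)c1nc(-c2ccc(Cl)cc2Cl)n(C)n1` returns only a limit in this assay, > 10000 nM, which is a limit of the assay and not a number; it is the one value sitting at the limit of > 10000 nM in this assay, at which 1 of the 3 values shown sits. Of the two numbers shown, compound 3 stands highest, with compound 1 as the nearest value, and the gap between them is beyond the scatter.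

Compound 4 `CCCN(c1nc(-c2ccc(Br)cc2C)n(C)n1)C(C1CC1)C1CC1` is not yet measured. It differs from compound 3 in one place: 4-bromo-2-methylphenyl in place of 4-chlorophenyl on an aromatic carbon. Among the measured compounds shown here, no step between measured compounds covers this change, so the only guide is the pair that shares the rest of the structure and differs in the substitution of this ring: in this assay compound 3 gives 33 nM and compound 1 gives 15 nM. The step from compound 3 to compound 4 is expected to be a modest lowering, a 2.2-fold lower number from compound 3 to compound 4 (0.34 log units; beyond the scatter), not far beyond the scatter. Compound 4 is expected to give about 15 nM in this assay, within a range of 5 nM to 50 nM.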

Compound 4, inhibition constant: 10 nM
Compound 4: middle estimate off by 1.5-fold (0.18 log units), on the high side, within the range that was stated.
By their numbers in this assay, from the lowest: compounds 4 and 1 (each within the scatter of the next); then compound 3. At a limit, above all of these: compound 2.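

In this assay, among these compounds, 4-bromo-2-methylphenyl in place of 4-chlorophenyl on this aromatic carbon gives a 3.3-fold lower number from compound 3 to compound 4 (0.52 log units; beyond the scatter), so the step is a real one and the position accepts an aryl group carrying a methyl group, where the earlier compounds carried only halogens on this ring. Compound 1 gives 15 nM and compound 4 gives 10 nM, values within the scatter of each other, so two different substitution patterns on this ring read alike. Nothing measured here bears on why this change lowers the number.

From the compounds shown here alone, the step swaps chlorine for bromine and adds the methyl group at once, so the share of each stays open. Also open, going by these compounds, is how this position would read with a methoxy group or an amine on the ring.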